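The source may hold more compounds than are shown below. What is called first, only, known or untested is meant among the compounds shown, and "the series" means these compounds.

Measured compounds:
compound 1 `Nc1nc(Cl)c(-c2cc3ccccc3s2)c(N[C@@H]2C[C@H](CO)[C@@H](O)[C@H]2O)n1`: > 25000 nM
compound 2 `Nc1ncc(-c2nc3ccccc3s2)c(N[C@@H]2C[C@H](CO)[C@@H](O)[C@H]2O)n1`: > 25000 nM
compound 3 `CCNc1nc(C)c(-c2nc3ccccc3s2)c(N[C@@H]2C[C@H](CO)[C@@H](O)[C@H]2O)n1`: 12000 nM

The three compounds share a core and were run in an ADME assay on cells (Homo sapiens) for cytotoxicity, read by polymerase chain reaction, with a stated time of 3 days; a higher number here means that more compound is tolerated, a lower number that less compound is tolerated. For compound 1 the value is a limit of the assay and not a number. For compound 2 the value is likewise a limit and not a number. Within the data shown here, compound 3 is therefore the only compound with a number in this assay, its half-maximal cytotoxic concentration standing at 12000 nM, while the two other values sit at the limit of > 25000 nM in this assay, at which 2 of the 3 values shown sit. Among the measured compounds shown here, no step between two measured compounds is available here, since no pair differs in a single place.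

The step to be followed leads from compound 3 to compound 4 `CCOC(=O)NCCNc1nc(C)c(-c2nc3ccccc3s2)c(N[C@@H]2C[C@H](CO)[C@@H](O)[C@H]2O)n1`. The change is (ethoxycarbonyl)amino in place of hydrogen on a saturated chain carbon, two bonds along the chain from a nitrogen on an aromatic ring; cut one bond further out, it reads ethylamino to (2-((ethoxycarbonyl)amino)ethyl)amino. For the measured compounds named here, with no measured step to lean on, the expected step of a 1.5-fold higher number from compound 3 to compound 4 (0.18 log units; within the scatter) is a small one, at or within the scatter, with a mild lean toward more compound being tolerated. Compound 4 is thus expected to show about 18000 nM in this assay, within a range from 6000 nM to 50000 nM.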

Compound 4, half-maximal cytotoxic concentration: 12000 nM
Estimate against measurement, compound 4: 1.5-fold (0.18 log units) above, and the stated range covers the measured number.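

In this assay, among these compounds, the first step at a single place shows no change at the digits printed from compound 3 to compound 4 (within the scatter). Among the compounds shown here, the saturated chain carbon, two bonds along the chain from a nitrogen on an aromatic ring, thus carries (ethoxycarbonyl)amino, with its 6 heavy atoms, hydrogen-bond donor and hydrogen-bond acceptors, and the reading for this pair stays within the scatter, something no earlier pair could show. The other compounds add no second step to set beside this one, and the values that are limits and not numbers give no size for any comparison: the limit of > 25000 nM in this assay, at which 2 of the 4 values shown sit.

For the compounds shown here, whether a free primary amine, a carboxylic acid or a longer chain in the same place would also leave the reading within the scatter remains open, as the single step covers one group on one chain. It is equally open whether (ethoxycarbonyl)amino would read the same way on the core of compound 1 or compound 2, and the compounds shown offer no explanation for the result of this step.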